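The compounds below may be only part of what the source reports. "The series", "measured", "known", "first", "only" and "open" are said of these compounds alone.

Measured compounds in this series:
- compound 1 `Nc1ccc(Nc2c(C(=O)NCc3ccc(F)cc3)nc(Br)c3cccnc23)cc1`: 4000 nM
- compound 2 `N[C@H]1CC[C@H](Nc2c(C(=O)NCc3cccc(C(F)(F)F)c3)nc(Br)c3cccnc23)CC1`: 15000 nM
- compound 3 `N[C@H]1CC[C@H](Nc2c(C(=O)Nc3ccccc3)nc(Br)c3cccnc23)CC1`: "not determined" (no result reported)

In a functional assay on MCF7 cells (Homo sapiens) for cytotoxicity, read by MTT assay, with a stated time of 72 h (a lower number here means a stronger inhibitor, a higher number a weaker inhibitor), compound 1 gives 4000 nM, the lower of the two numbers available. Compound 2 gives 15000 nM, a higher number that lies beyond the usual scatter; compound 2 differs from compound 1 in more than one place, so the two values can only be set side by side. Compound 3 carries no number.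

Compound 4 `NCCCCCCNc1c(C(=O)NCc2ccc(F)cc2)nc(Br)c2cccnc12` differs from compound 1 in one place: 6-aminohexyl in place of 4-aminophenyl on a nitrogen on an aromatic ring. Within the data shown here, no measured pair tracks this change, so the expectation rests on compound 1 alone. A ring is exchanged for a chain of the same heavy-atom count, and a moderate move toward a higher number is expected, near the edge of the scatter. Compound 4 is estimated at 8000 nM (range 3000 nM to 25000 nM), a step of a 2.0-fold higher number from compound 1 to compound 4 (0.30 log units; within the scatter) expected as a modest loss.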

Compound 4, half-maximal inhibitory concentration: 2000 nM
Compound 4: the middle estimate sits 4.0-fold (0.60 log units) above what was measured, outside the stated range (below it).
By their numbers in this assay, from the lowest: compounds 4 and 1 (each within the scatter of the next); then compound 2.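

Exchanging 4-aminophenyl for 6-aminohexyl on a nitrogen on an aromatic ring gives a 2.0-fold lower number from compound 1 to compound 4 (0.30 log units; within the scatter) in this assay and so does not separate the two compounds. Among these compounds, this position therefore accepts an open chain in place of the aromatic ring with no change beyond the scatter, which the earlier compounds could not show. Nothing at hand accounts for this result.

Still open, from the compounds shown here alone, is whether a shorter chain would hold this level. Also open, going by these compounds, is whether the same chain ending in a carboxylic acid instead of the amine would do so.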